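Trimethoxyphenyl in Place of Phenyl on the Shared Core

A few compounds are considered here, and "the series" means these few. Any claim that something is new, unique, unknown or untested is made for them only; others in the source may bear on it.

Measured so far:
compound 1 `COc1cc(/C=C/C(=O)c2cccc(-n3cc(-c4ccccc4)[nH]c3=O)c2)ccc1O`: 4110 nM
compound 2 `COc1cc(/C=C/C(=O)c2cccc(-n3cc(-c4ccccc4)[nH]c3=O)c2)cc(OC)c1OC`: 1620 nM

Two compounds of the series have been run in a functional assay on OVCAR-8 cells (Homo sapiens) for inhibition; on this read-out higher numbers stand for weaker inhibition of growth and lower numbers for stronger inhibition of growth. Compound 1 `COc1cc(/C=C/C(=O)c2cccc(-n3cc(-c4ccccc4)[nH]c3=O)c2)ccc1O` gives 4110 nM in this assay. Compound 2 `COc1cc(/C=C/C(=O)c2cccc(-n3cc(-c4ccccc4)[nH]c3=O)c2)cc(OC)c1OC` gives 1620 nM in this assay, the lower of the two numbers; the gap to compound 1 lies beyond the usual scatter, so compound 2 is the stronger inhibitor of the pair on present evidence.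

Compound 3 `COc1cc(/C=C/C(=O)c2cccc(-n3cc(-c4cc(OC)c(OC)c(OC)c4)[nH]c3=O)c2)cc(OC)c1OC` is not yet measured. It differs from compound 2 in one place: 3,4,5-trimethoxyphenyl in place of phenyl on an aromatic carbon. No comparable exchange at this position exists among the measured compounds, so the size of its effect cannot be read from a measured step. With compound 2 at 1620 nM as the starting point, the expectation for compound 3 in this assay is a small step downward, a 1.4-fold lower number from compound 2 to compound 3 (0.13 log units; within the scatter), possibly not beyond the scatter. Compound 3 is therefore estimated at 1200 nM, with a range from 400 nM to 3500 nM.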

Compound 3, concentration for 50% growth inhibition: 2320 nM
The estimate for compound 3 lay 1.9-fold (0.29 log units) below the measured number; measured number inside the range.
By their numbers in this assay, from the lowest: compounds 2, 3 and 1 (each within the scatter of the next, the first and the last beyond it).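

In this assay, the first step measured at this position, on an aromatic carbon of a five-membered aromatic ring with 2 nitrogen, is a 1.4-fold higher number from compound 2 to compound 3 (0.16 log units; within the scatter). Going from phenyl to 3,4,5-trimethoxyphenyl takes the group from 6 to 12 heavy atoms and adds 3 hydrogen-bond acceptors, yet compound 2 and compound 3 cannot be told apart on this read-out, so in this one pair the position accepts the larger group without a step beyond the scatter. No measurement on hand accounts for this outcome.

A single exchange cannot show whether the three methoxy groups act alike or whether their contributions offset one another, so a single methoxy group or a fluorine on the phenyl would be the informative comparison. Going by these compounds, whether this position stays as permissive for an amine, a carboxylic acid or a longer alkyl chain in place of the aromatic ring remains open, as does whether the same exchange would give a similar step on the core of compound 1.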